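The source may report more compounds than this note shows. Statements on the series, on what has been measured and on what is new or still open speak of the compounds shown alone.

Measured compounds:
- compound 1, `CCCn1c(=O)n(CC)c(=O)c2[nH]cnc21`, with 1300 nM in a functional assay (trachea) with Cavia porcellus as the target; a higher number here means that more compound is needed for the effect, a lower number that less compound is needed
- compound 2, `CCCn1c(=O)n(CCC(N)=O)c(=O)c2[nH]cnc21`, with 13100 nM in this assay

Among these two numbers compound 1 holds the lowest; its nearest neighbour is compound 2, reached by a 10-fold higher number from compound 1 to compound 2 (1.00 log units; beyond the scatter), a step that comes from adding a carbamoyl group further out on the same chain.

Compound 3, `CCCn1c(=O)n(C)c(=O)c2[nH]cnc21`, takes a shorter path from compound 1: hydrogen in place of methyl on a saturated chain carbon bound to an aromatic nitrogen. The chain on that ring nitrogen thus shrinks from ethyl to methyl, and nothing polar is added. Among the compounds with values here, the only measured step, from compound 1 to compound 2, concerns a different kind of change, so it bears on this one only loosely; it shows that the chain at this nitrogen can move the number noticeably, but not what a mere shortening does. With no closer comparison available, a small step in this assay is expected for compound 3, most likely a slight rise in the number, as a 1.7-fold higher number from compound 1 to compound 3 (0.23 log units; within the scatter). Compound 3 is therefore estimated at 2200 nM, with a likely range from 800 nM to 6500 nM.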

Compound 3, half-maximal effective concentration: 1600 nM
Compound 3: the middle estimate sits 1.4-fold (0.14 log units) above what was measured; low and high end bracket the measured number.
By their numbers in this assay, from the lowest: compounds 1 and 3 (each within the scatter of the next); then compound 2.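

In this assay shortening the chain on this ring nitrogen from ethyl to methyl, a change of one carbon, gives a 1.2-fold higher number from compound 1 to compound 3 (0.09 log units; within the scatter) and so leaves compound 1 and compound 3 indistinguishable. The number therefore does not respond to this small change in chain length, which puts the earlier step in context: swapping carbamoylmethyl for hydrogen on the same chain carbon gives an 8.2-fold lower number from compound 2 to compound 3 (0.91 log units; beyond the scatter) and so, among these three compounds, only compound 2, with its carbamoyl group, stands apart. No measurement at hand explains why compound 2 needs more compound for the effect.

On these data alone, whether a longer chain such as butyl on this nitrogen would also leave the number in place, or whether the chain can be lost altogether with only hydrogen on the nitrogen, remains open. As far as these compounds go, it is also open whether the carbamoyl group itself sets the number for compound 2, something that a carboxylic acid or an amine on the same chain could help to separate from the added chain length.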